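Hydroxyoxetane for hydroxyisopropyl on the pyrazole side chain

The source may hold more compounds than are shown below. What is called first, only, known or untested is meant among the compounds shown, and "the series" means these compounds.

Compound 1, `Cc1c(Nc2nc(N)c3c(C#N)c(N4CCC[C@H]4C)n(C)c3n2)cnn1CC(C)(C)O`, is the reference point of this small set. In an assay on isolated protein for inhibition of Leucine-rich repeat serine/threonine-protein kinase 2 variant G2019S (Homo sapiens), read by TR-FRET and LanthaScreen, with stated times of 50 min and 30 min, in the presence of a further agent that is not named here (on this read-out lower numbers stand for stronger inhibition and higher numbers for weaker inhibition), compound 1 gives 35 nM, the lowest of the three numbers measured. Compound 2, `C[C@@H]1CCCN1c1[nH]c2ncnc(N)c2c1C#N`, gives 201 nM in this assay, a higher number that lies beyond the scatter of the method. Compound 3, `C[C@@H]1CCCN1c1c(C(N)=O)c2c(N)ncnc2n1C`, gives 2240 nM, the highest of the three and also beyond the scatter relative to compound 1. Within the data shown here, compound 2 and compound 3 share only part of the core with compound 1 and differ from it in more than one place, so no single step between measured compounds is available for comparison.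

Compound 4, `Cc1c(Nc2nc(N)c3c(C#N)c(N4CCC[C@H]4C)n(C)c3n2)cnn1CC1(O)COC1`, is not yet measured. Its difference from compound 1 is 3-hydroxyoxetan-3-yl in place of 1-hydroxy-1-methylethyl on a saturated chain carbon bound to an aromatic nitrogen. The hydroxyl donor is kept; the 3-hydroxyoxetan-3-yl group brings one more acceptor and a four-membered ring in place of the two methyl branches of 1-hydroxy-1-methylethyl. Nothing in the measured set speaks to this exact exchange. The expectation is a step of a 1.4-fold higher number from compound 1 to compound 4 (0.15 log units; within the scatter), that is, at most a small weakening and most likely none beyond the scatter. Compound 4 is therefore estimated at 50 nM, within a range of 20 nM to 130 nM.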

Compound 4, half-maximal inhibitory concentration: 10 nM
Compound 4: the middle estimate sits 5.0-fold (0.70 log units) above what was measured; the measured number lies below the stated range.
By their numbers in this assay, from the lowest: compound 4; then compound 1; then compound 2; then compound 3.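

In this assay, among these compounds, 3-hydroxyoxetan-3-yl in place of 1-hydroxy-1-methylethyl on a saturated chain carbon bound to an aromatic nitrogen gives a 3.5-fold lower number from compound 1 to compound 4 (0.54 log units; beyond the scatter); this is the only single-place step so far, and it runs toward stronger inhibition. This place therefore accepts a four-membered non-aromatic ring instead of the methyl branches, and on this one pair the added ring oxygen comes with a gain rather than a loss. No measurement bearing on the origin of the step is at hand, so it stands as an observation on one pair of compounds.

The compounds shown do not separate the ring from its oxygen: 1-hydroxycyclobutyl would keep the four-membered ring and hydroxyl without the ring oxygen, and oxetan-3-yl would keep the ring oxygen without the hydroxyl. Also open, from the compounds shown here alone, is how this place responds to a group of a different kind, such as a primary amine or a carboxylic acid in place of the hydroxyl, and whether the step carries over to any other core.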